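A few compounds are considered here, and "the series" means these few. Any claim that something is new, unique, unknown or untested is made for them only; others in the source may bear on it.

Compound 1 `Clc1cncc(Cl)c1N/N=C/c1ccccc1-c1c(Cl)cccc1Cl`: 93 nM
Compound 2 `CN(C(=O)c1ccccc1-c1ccccc1)C(C)(C)c1cc(C(F)(F)F)cc(C(F)(F)F)c1`: 295 nM

In an assay on CHO cells for displacement of a labelled ligand from Substance-P receptor (Homo sapiens) (on this read-out higher numbers stand for weaker inhibition and lower numbers for stronger inhibition), compound 1 gives 93 nM, the lowest of the two numbers shown; compound 2 gives 295 nM, a higher number, and the gap between them lies beyond the scatter. Compound 3 `Clc1ccccc1-c1ccccc1/C=N/Nc1c(Cl)cncc1Cl` has not yet been measured in this assay. It differs from compound 1 in one place: hydrogen in place of chloro on an aromatic carbon. Within the data shown here, no step between measured compounds shows what this change does here, so the expectation rests on the change alone. A modest weakening is expected, as a step of a 1.9-fold higher number from compound 1 to compound 3 (0.29 log units; within the scatter). Compound 3 is estimated at 180 nM, with a range from 60 nM to 600 nM.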

Compound 3, inhibition constant: 174 nM
The estimate for compound 3 lay 1.0-fold (0.01 log units) above the measured number; low and high end bracket the measured number.
By their numbers in this assay, from the lowest: compounds 1, 3 and 2 (each within the scatter of the next, the first and the last beyond it).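

Replacing one chloro group with hydrogen turns the 2,6-dichlorophenyl group into 2-chlorophenyl and gives, in this assay, a 1.9-fold higher number from compound 1 to compound 3 (0.27 log units; within the scatter), so this position accepts hydrogen with no change beyond the scatter. The second chloro group is therefore not required to keep the number in this range. No measurement bears on why this is so.

The compounds shown leave open whether the remaining chloro group can also be replaced by hydrogen. They also leave open how a methoxy group or an amine in place of chloro would read.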